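Replacing a chlorophenyl arm with a methoxyphenyl arm

The compounds below may be only part of what the source reports. "The series", "measured", "known", "first", "only" and "open" are said of these compounds alone.

Measured in an ADME assay on microsomes from liver (Homo sapiens) for metabolic stability, tested at 2.5 uM; a lower number here means slower removal, a higher number faster removal of the compound:
compound 1 `O=S(=O)(c1ccc(F)c(Cl)c1)c1cnc2cc(F)ccc2c1-c1ccc(Cl)cc1` gives 0.39 mL/min
compound 2 `COc1ccc(-c2c(S(=O)(=O)c3ccc(C)c(C)c3)cnc3cc(F)ccc23)cc1` gives 4.13 mL/min
compound 3 `O=S(=O)(c1ccc(F)c(Cl)c1)c1cnc2cc(F)ccc2c1-c1cccc(Cl)c1` gives 0.66 mL/min

Compound 3 stands second highest of these three numbers. Compound 1 lies nearest, and the step of a 1.7-fold higher number from compound 1 to compound 3 (0.23 log units; within the scatter) falls within the scatter. Compound 2 lies furthest, at a higher number beyond the scatter.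

Compound 4 `COc1ccc(-c2c(S(=O)(=O)c3ccc(F)c(Cl)c3)cnc3cc(F)ccc23)cc1` arises from compound 3 by 4-methoxyphenyl in place of 3-chlorophenyl on an aromatic carbon. Going by the values given here, no measured step carries this same change. Among the compounds with values here, the only single-change step known, a 1.7-fold higher number from compound 1 to compound 3 (0.23 log units; within the scatter), moves a chlorine on that ring and stays within the scatter. Compound 2 also bears 4-methoxyphenyl but differs in its sulfonyl aryl as well, so it offers only a hint toward a higher number.

Compound 4 is therefore expected to rise, a 2.3-fold higher number from compound 3 to compound 4 (0.36 log units; beyond the scatter), to an estimated 1.5 mL/min with a range of 0.5 mL/min to 4.5 mL/min.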

Compound 4, intrinsic clearance in a liver preparation (reported as CLH), per the amount of preparation that the assay uses: 1.08 mL/min
Beside the measured number, compound 4's estimate is 1.4-fold (0.14 log units) above it; measured number inside the range.
By their numbers in this assay, from the lowest: compounds 1, 3 and 4 (each within the scatter of the next, the first and the last beyond it); then compound 2.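

In this assay, the exchange of 3-chlorophenyl for 4-methoxyphenyl on the aromatic carbon opposite the ring nitrogen stays within the scatter (a 1.6-fold higher number from compound 3 to compound 4 (0.21 log units; within the scatter)), while methoxy in place of chloro goes beyond it (a 2.8-fold higher number from compound 1 to compound 4 (0.44 log units; beyond the scatter)). With 4-methoxyphenyl held constant, 3-chloro-4-fluorophenyl in place of 3,4-dimethylphenyl on the sulfonyl sulfur also goes beyond the scatter (a 3.8-fold lower number from compound 2 to compound 4 (0.58 log units; beyond the scatter)), so the sulfonyl aryl can now be read alone. No available evidence explains these steps.
The compounds shown leave open how an amine or a carboxylic acid on this aryl ring would read in this assay.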